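The compounds below may be only part of what the source reports. "The series", "measured", "known", "first", "only" and "open" are said of these compounds alone.

Compound 1 `O=C(CCCCCCc1ccccc1)N1CCCC1` sits in an assay on HEK293 cells for inhibition of N-acylethanolamine-hydrolyzing acid amidase (Rattus norvegicus), read by LC-MS, with a stated time of 30 min (on this read-out higher numbers stand for weaker inhibition and lower numbers for stronger inhibition), at 12900 nM. Compound 2 `O=C(O)c1ccc(CCCCCCC(=O)N2CCCC2)cc1` reaches only the assay limit of > 100000 nM in this assay and so carries no number of its own. Among the compounds with values here, the single measured step, an at least 7.7-fold higher number from compound 1 to compound 2 (0.88 log units; beyond the scatter), rests on a limit of > 100000 nM in this assay, at which 1 of the 2 values shown sits, and sets only a floor for its size. Compound 3 `COC(=O)c1ccc(CCCCCCC(=O)N2CCCC2)cc1` differs from compound 2 by methyl in place of hydrogen on an oxygen next to a carbonyl group. Within the data shown here, no measured step covers this change, so only a loose expectation follows: compound 3 is expected to shift by an at least 2.5-fold lower number from compound 2 to compound 3 (0.39 log units; beyond the scatter) in this assay, back toward a readable number. The estimate for compound 3 in this assay is 40000 nM, within 10000 nM to 150000 nM.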

Compound 3, half-maximal inhibitory concentration: > 100000 nM
Compound 3 ended at the assay's limit; the forecaster's own chance of this, stated with the estimate: 40%; at least 2.5-fold (0.39 log units) between middle value and limit.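

In this assay compound 3 carries a limit, > 100000 nM, and not a number. With methoxycarbonyl the read-out shows an at least 7.7-fold higher number from compound 1 to compound 3 (0.88 log units; beyond the scatter), so methyl on the oxygen does not restore the readable number lost with carboxy. The change from carboxy to methoxycarbonyl itself cannot be read, since both values are limits: the limit of > 100000 nM in this assay, at which 2 of the 3 values shown sit.

Going by these compounds, whether any group on this aromatic carbon keeps a readable number, a fluorine or an amine for instance, stays open. On these data alone, how far compound 2 and compound 3 lie past the limit also stays open.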